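Swapping fluoro for chloro on a cinnamate ester

The compounds below may be only part of what the source reports. "The series", "measured", "known", "first", "only" and "open" are said of these compounds alone.

Three esters share one core, and each has been tested in a functional assay on the whole organism (strain Kunming) with Mus musculus as the target, with a stated time of 0.5 h, at a dose of 300 mg/kg by the intraperitoneal route; a higher number here means a weaker effect of the compound at the dose given, a lower number a stronger effect. Compound 1, `COc1ccccc1/C=C/C(=O)OC/C=C/c1cc(OC)c(OC)cc1OC`, gives 100%. Compound 2, `COc1cc(OC)c(OC)cc1/C=C/COC(=O)/C=C/c1ccc(OC)c(OC)c1`, gives 75%. Compound 3, `COc1cc(OC)c(OC)cc1/C=C/COC(=O)/C=C/c1ccc(F)cc1`, gives 75%. Compound 3 stands level with compound 2 at the digits printed, the two together being the lowest of the three numbers, and sits furthest from compound 1, as a number 25 percentage points lower from compound 1 to compound 3 (beyond the scatter) shows. The step of no change at the digits printed from compound 2 to compound 3 (within the scatter) is within the scatter, while a number 25 percentage points lower from compound 1 to compound 2 (beyond the scatter) is modest.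

Compound 4, `COc1cc(OC)c(OC)cc1/C=C/COC(=O)/C=C/c1ccc(Cl)cc1`, differs from compound 3 in one place: chloro in place of fluoro on an aromatic carbon. For the measured compounds named here, no measured step swaps one halogen for another, so nothing bears directly on this change; the nearest comparison, no change at the digits printed from compound 2 to compound 3 (within the scatter), shows that exchanging the whole aryl group left the number unchanged. The expectation is therefore a step of about no change at the digits printed from compound 3 to compound 4 (within the scatter) in this assay, that is, none beyond the scatter. Compound 4 is estimated to give 75%, within a range from 55% to 95%.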

Compound 4, a percentage reported as activity, at one dose (the size of the read-out at that dose, not a potency): 50%
Estimate against measurement, compound 4: 25 percentage points above; the measured number lies below the stated range.
By their numbers in this assay, from the lowest: compound 4; then compounds 2 and 3 (each within the scatter of the next); then compound 1.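

In this assay this position on the aromatic ring proves sensitive to a single atom: a number 25 percentage points lower from compound 3 to compound 4 (beyond the scatter) follows from chloro in place of fluoro, whereas exchanging the whole aryl group gave no change at the digits printed from compound 2 to compound 3 (within the scatter) earlier. For the compounds shown here, the 4-chlorophenyl group also separates compound 4 from both other aryl groups, with a number 25 percentage points lower from compound 2 to compound 4 (beyond the scatter) and a number 50 percentage points lower from compound 1 to compound 4 (beyond the scatter), which makes compound 4 the lowest of the four and gives the only large step in this set. No available evidence explains why this one exchange moves the number.

Going by these compounds, whether a bromo group or a methyl group in the same place would extend the change or reverse it remains open. These numbers each come from a single dose, so how the compounds compare in potency is also unknown.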